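The source may hold more compounds than are shown below. What is called first, only, known or untested is meant among the compounds shown, and "the series" means these compounds.

Measured so far in a functional assay on HEp-2 cells (Homo sapiens) for cytotoxicity, read by sulforhodamine B assay, with a stated time of 48 h; a higher number here means a weaker inhibitor, a lower number a stronger inhibitor:
- compound 1 `CC(=O)N1N=C(c2cccc3ccccc23)CC1c1cccc(Br)c1` — 9880 nM
- compound 2 `CC(=O)N1N=C(c2cccc3ccccc23)CC1c1ccco1` — 17000 nM
- compound 3 `O=CCN1N=C(c2ccc3ccccc3c2)CC1c1cccc(Br)c1` — 8780 nM

The three measured values all lie within the usual scatter of one another, so no order among them is read. Among the measured compounds shown here, the one measured step with a single structural change is a 1.7-fold higher number from compound 1 to compound 2 (0.24 log units; within the scatter), the change being (furan-2-yl in place of 3-bromophenyl on a saturated ring carbon).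

Compound 3 and compound 1 share the same atoms joined differently; the difference between the two cores is not broken down here. Compound 4 `O=CCN1N=C(c2ccc3ccccc3c2)CC1c1ccco1` is not yet measured in this assay. It differs from compound 3 by furan-2-yl in place of 3-bromophenyl on a saturated ring carbon. This is the same kind of change as from compound 1 to compound 2, not the same: around the place, the ring atom bears a formylmethyl group (3 heavy atoms) in compound 3 and compound 4, where in compound 1 and compound 2 it bears an acetyl group (3 heavy atoms).

The expectation for compound 4 rests on that single earlier step: because a 1.7-fold higher number from compound 1 to compound 2 (0.24 log units; within the scatter) stayed within the scatter, the corresponding step is estimated as a 1.7-fold higher number from compound 3 to compound 4 (0.23 log units; within the scatter), with the core difference adding uncertainty. Compound 4 is thus estimated at 15000 nM in this assay, expected to fall between 7000 nM and 35000 nM.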

Compound 4, half-maximal inhibitory concentration: 19000 nM
Beside the measured number, compound 4's estimate is 1.3-fold (0.10 log units) below it; measured number inside the range.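

In this assay, furan-2-yl in place of 3-bromophenyl on a saturated ring carbon gives a 2.2-fold higher number from compound 3 to compound 4 (0.34 log units; beyond the scatter), a modest step that reaches just beyond the scatter. Set beside the earlier step, the change reads alike on the two cores, and no difference between the cores can be claimed from these pairs: the same change on two cores in this assay, a 1.7-fold higher number (0.24 log units; within the scatter) from compound 1 to compound 2 and a 2.2-fold higher number (0.34 log units; beyond the scatter) from compound 3 to compound 4, 1.3-fold (0.10 log units) apart, within the scatter of two such steps

Among the compounds shown here, this supports carrying the change between these two cores as a working estimate, but it rests on only two pairs, one step within the scatter and one only just beyond it, so it does not firmly establish that furan-2-yl gives a higher number than 3-bromophenyl, nor show that the step would hold on any other core, and the separate contributions of the formylmethyl group in compound 3 and compound 4, the acetyl group in compound 1 and compound 2, and the different joining of the atoms remain unresolved.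

The compounds shown leave open how an amine or a carboxylic acid would read in place of furan-2-yl or 3-bromophenyl on that saturated ring carbon. They also leave open what a longer chain in place of the formylmethyl or acetyl group would do to the number in this assay.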